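Hydroxy to Vinyl on a Leukotriene B4 Receptor Series

The compounds below may be only part of what the source reports. "The series", "measured", "known", "first", "only" and "open" are said of these compounds alone.

Three compounds share one core. Compound 1 `CCCc1cc(C(C)=O)c(O)cc1OCCCCC#N` gives 84% in an assay on isolated protein for inhibition of leukotriene B4 receptor 1 (Homo sapiens), tested at 10 uM; on this read-out lower numbers stand for less inhibition and higher numbers for more inhibition at the one concentration tested (going by the name of the read-out). For the measured compounds named here, compound 2 `CCCCCCc1cc(C(C)=O)c(O)cc1OCCCCC#N` gives 51% in this assay, and a number 33 percentage points lower from compound 1 to compound 2 (beyond the scatter) is the only single-site step measured so far. Compound 3 `CC(=O)c1cc(CO)c(OCCCCCCC#N)cc1O` gives 40% in this assay, the lowest of the three numbers; compound 2 sits above it and compound 1 further above, both beyond the scatter. Going by the values given here, compound 3 differs from compound 1 in two places, so their values show only that compound 1 stands far higher.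

Compound 4 `C=CCc1cc(C(C)=O)c(O)cc1OCCCCCCC#N` is not yet measured. It differs from compound 3 by vinyl in place of hydroxy on a saturated chain carbon bound to an aromatic carbon; cut one bond further out, the same difference reads hydroxymethyl to allyl. Among the compounds with values here, no measured step swaps a hydroxy for a vinyl. Within the data shown here, the one step that exists, a number 33 percentage points lower from compound 1 to compound 2 (beyond the scatter), lengthens a chain at another place and shows that a single change on this core can move the number by a large amount. Compound 4 carries an allyl where compound 1 carries a propyl and compound 3 a hydroxymethyl, so a rise toward compound 1 is expected, tempered since compound 3 gives 40% with the same nitrile chain as compound 4. Compound 4 is therefore estimated at 60%, within 35% to 85%. The expected step is a number 20 percentage points higher from compound 3 to compound 4 (beyond the scatter).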

Compound 4, a percentage reported as inhibition, at one concentration (the size of the read-out at that concentration, not a potency): 97%
Compound 4: middle estimate off by 37 percentage points, on the low side; measured number above the stated range.
By their numbers in this assay, from the lowest: compound 3; then compound 2; then compound 1; then compound 4.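

In this assay, putting vinyl in place of hydroxy on a saturated chain carbon bound to an aromatic carbon gives a number 57 percentage points higher from compound 3 to compound 4 (beyond the scatter), the first step measured at this place and a large one. For the compounds shown here, until now the only single-site step was the propyl in place of hydrogen, a number 33 percentage points lower from compound 1 to compound 2 (beyond the scatter), which lay at another place and ran downward; the new step shows that a single change on this core can also raise the number by a large amount, and that the nitrile chain of compound 3 does not by itself hold the number low, since compound 4 carries the same chain and gives 97%. Nothing measured here bears on why the number moves at this place.

The compounds shown leave open whether the double bond of the vinyl matters, or whether an ethyl in the same place would carry the number as far. They also leave open how an amine or a carboxylic acid on that chain carbon would read in this assay.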